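The source may hold more compounds than are shown below. What is called first, only, known or untested is meant among the compounds shown, and "the series" means these compounds.

Compound 1 `COc1cccc(OC)c1OCCNCCOc1ccccc1OCc1cccc(Cl)c1`: 8.12
Compound 2 `COc1cccc(OC)c1OCCNCCOc1ccccc1OCc1ccccc1[N+](=O)[O-]`: 8.2
Compound 3 `COc1cccc(OC)c1OCCNCCOc1ccccc1OCc1ccc([N+](=O)[O-])cc1`: 8.58

The three measured compounds share one core and differ only in the group on the saturated chain carbon bound to an oxygen on an aromatic ring. In a functional assay on Vas deferens for antagonist activity at Alpha-1A adrenergic receptor (Rattus norvegicus) (on this read-out lower numbers stand for lower potency and higher numbers for higher potency (the scale is a negative logarithm)), compound 3 gives the highest of the three numbers: the step of a number 0.38 log units higher from compound 2 to compound 3 (beyond the scatter) and the step of a number 0.46 log units higher from compound 1 to compound 3 (beyond the scatter) both lie beyond the scatter, while the step of a number 0.08 log units higher from compound 1 to compound 2 (within the scatter) does not.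

Compound 4 `COc1cccc(OC)c1OCCNCCOc1ccccc1OCc1ccc(OC(C)C)cc1` is not yet measured. It differs from compound 3 in one place: isopropoxy in place of nitro on an aromatic carbon. Going by the values given here, no measured step replaces nitro with isopropoxy, so nothing direct is known about this change. The two steps that end at compound 3, a number 0.46 log units higher from compound 1 to compound 3 (beyond the scatter) and a number 0.38 log units higher from compound 2 to compound 3 (beyond the scatter), show only that 4-nitrophenyl on that chain carbon gave modestly higher numbers than 3-chlorophenyl and 2-nitrophenyl, and that all three variations stayed close together. Compound 4 is therefore expected to land near the measured compounds in this assay. The expected step of a number 0.28 log units lower from compound 3 to compound 4 (within the scatter) is estimated to lie within the scatter, with a modest drop as the more likely direction. The estimate for compound 4 is 8.3, with a range from 7.7 to 8.9.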

Compound 4, negative logarithm of the antagonist equilibrium constant: 8.17
For compound 4 the middle estimate is 0.13 log units above the measured one; the measured number falls inside the stated range.
By their numbers in this assay, from the lowest: compounds 1, 4 and 2 (each within the scatter of the next); then compound 3.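

In this assay, the group on the aromatic carbon para to a large group can be exchanged with an effect beyond the scatter: a number 0.41 log units lower from compound 3 to compound 4 (beyond the scatter), so the higher number of compound 3 does not carry over to every group at this place. With isopropoxy there, the number sits level with the other two, as a number 0.03 log units lower from compound 2 to compound 4 (within the scatter) and a number 0.05 log units higher from compound 1 to compound 4 (within the scatter) both lie within the scatter, which leaves compound 3 as the only one of the four set apart from the rest. Nothing available here bears on why nitro and isopropoxy differ at this place.

From the compounds shown here alone, whether the higher number is particular to nitro stays open, since an amine or a carboxylic acid on the same aromatic carbon would show how other groups compare with both nitro and isopropoxy. The effect of place is only partly covered, as nitro is compared between 2-nitrophenyl and 4-nitrophenyl while isopropoxy appears only as 4-isopropoxyphenyl.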